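Adding chloro to compound 3: working notes

The compounds below may be only part of what the source reports. "The series", "measured", "known", "first", "only" and "open" are said of these compounds alone.

Of the compounds shown here, three have been read in an ADME assay on HepG2 cells (Homo sapiens) for cytotoxicity, read by CellTiter-Glo and ATP content, with a stated time of 48 h; a lower number here means a stronger inhibitor, a higher number a weaker inhibitor. Compound 1 `Cc1ccnc(NC(=O)N2CCN(c3cccc(C(F)(F)F)c3)CC2)c1` gives 7000 nM. Compound 3 `Cc1cc(C)nc(NC(=S)N2CCN(c3ccc(C(F)(F)F)cn3)CC2)c1` gives 15800 nM, the higher of the two actual numbers. The gap between these two compounds lies beyond the scatter of repeated measurements. Compound 2 `Cc1ccnc(NC(=S)N2CCN(c3ccccc3C(F)(F)F)CC2)c1` is reported at >= 114000 nM, which is a limit of the assay and not a number.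

Compound 4 `Cc1cc(C)nc(NC(=S)N2CCN(c3ncc(C(F)(F)F)cc3Cl)CC2)c1` is compound 3 with a single change, chloro in place of hydrogen on an aromatic carbon, ortho to a large group, two atoms from the ring nitrogen and meta to a trifluoromethyl group. Within the data shown here, no two measured compounds differ in one place only, so the series holds no direct measure of this change. The expectation therefore starts from compound 3 at 15800 nM, and no large shift in this assay is expected. The expected step is a 1.3-fold lower number from compound 3 to compound 4 (0.12 log units; within the scatter), a small move towards a lower number that would stay within the scatter. For compound 4 the estimated value is 12000 nM, with an expected range of 4500 nM to 35000 nM.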

Compound 4, half-maximal inhibitory concentration: 30000 nM
Beside the measured number, compound 4's estimate is 2.5-fold (0.40 log units) below it, within the range that was stated.
By their numbers in this assay, from the lowest: compound 1; then compounds 3 and 4 (each within the scatter of the next). At a limit, above all of these: compound 2.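

In this assay the series now holds its first direct measure of a single change: chloro in place of hydrogen on an aromatic carbon, ortho to a large group, two atoms from the ring nitrogen and meta to a trifluoromethyl group, gives a 1.9-fold higher number from compound 3 to compound 4 (0.28 log units; within the scatter). That step lies within the scatter, so this position carries the chloro with no readable change in the number, and compound 3 and compound 4 cannot be put in order. Compound 2 remains the only compound held at a limit, which is a limit of the assay and not a number: the limit of >= 114000 nM in this assay, at which 1 of the 4 values shown sits.

No other pair among the compounds shown differs in one place, so no other step can be read, and one step within the scatter gives no basis for a cause or for a trend. On these data alone, whether a fluoro, a methoxy or a nitrile at this position would read any differently stays open, as does whether chloro gives a similar step on a parent other than compound 3.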